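The source may hold more compounds than are shown below. What is called first, only, known or untested is meant among the compounds shown, and "the series" means these compounds.

Measured in a functional assay on KYSE-450 cells (Homo sapiens) for inhibition, read by MTT assay, with a stated time of 48 h; on this read-out higher numbers stand for weaker inhibition and lower numbers for stronger inhibition:
- compound 1 `COc1cc(NCc2ccc(Cl)cc2)cc(OC)c1OC`: > 80000 nM (a limit)
- compound 2 `COc1cc(NCc2ccc(Br)cc2)cc(OC)c1OC`: > 80000 nM (a limit)

Compound 2 stands at > 80000 nM, which is a limit and not a number. Both compounds share this position: the limit of > 80000 nM in this assay, at which 2 of the 2 values shown sit. Compound 3 `COc1cc(NCc2cccc(O)c2)cc(OC)c1OC` carries 3-hydroxyphenyl in place of 4-bromophenyl on a saturated chain carbon bound to a nitrogen on an aromatic ring. Going by the values given here, the only measured step is a step that the two limits leave unreadable from compound 1 to compound 2, with bromo in place of chloro on an aromatic carbon, so no measured step gives a size for this change. In this assay, only a small step or none is therefore expected, and its direction is uncertain. The estimated step is an at least 1.1-fold lower number from compound 2 to compound 3 (0.05 log units; that floor lies within the scatter). The estimate for compound 3 is 70000 nM, with an expected range of 25000 nM to 160000 nM.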

Compound 3, half-maximal inhibitory concentration: 71300 nM
Beside the measured number, compound 3's estimate is 1.0-fold (0.01 log units) below it; the range from low to high includes it.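

In this assay, going by these compounds alone, compound 3 is the first compound here to give a number and not a limit, so the 3-hydroxyphenyl group at this position brings the read-out into the measurable range. On these data alone, the change gives an at least 1.1-fold lower number from compound 2 to compound 3 (0.05 log units; that floor lies within the scatter) and an at least 1.1-fold lower number from compound 1 to compound 3 (0.05 log units; that floor lies within the scatter); each is only a floor, so the true size of the change remains unknown. Compound 1 and compound 2 stay at a limit: the limit of > 80000 nM in this assay, at which 2 of the 3 values shown sit.

As far as these compounds go, whether an amine or a carboxylic acid in place of the hydroxy group would move the number further remains open.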